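A few compounds are considered here, and "the series" means these few. Any claim that something is new, unique, unknown or untested is made for them only; others in the source may bear on it.

Measured so far in a functional assay for inhibition, with Homo sapiens as the target; a lower number here means a stronger inhibitor, a higher number a weaker inhibitor:
compound 1 `CCCc1nc(C)c2cnnc(O)n12` gives 56800 nM
compound 2 `CCCc1nnc(O)n2c(CCC)nc(C)c12` gives 16000 nM
compound 3 `CCCc1ncn2c(O)nncc12` gives > 48000 nM, which is a limit of the assay and not a number.

Between compound 2 and compound 1 the structural change is hydrogen in place of propyl on an aromatic carbon, and it produced a 3.6-fold higher number from compound 2 to compound 1 (0.55 log units; beyond the scatter). Compound 4 `Oc1nncc2cncn12` has not yet been measured in this assay. It arises from compound 3 by hydrogen in place of propyl on an aromatic carbon, the same kind of change; the place differs, since here it lies on an aromatic carbon of a five-membered aromatic ring with 2 nitrogen, next to the ring nitrogen and two ring bonds from it, rather than on a six-membered aromatic ring with 3 nitrogen, ortho to a fused ring and para to a hydroxy group. The difference between the cores of compound 3 and compound 2 is not broken down here. For compound 4 a step that the limit leaves unreadable from compound 3 to compound 4 is expected, beside the earlier one, because compound 3 already sits at the limit of > 48000 nM in this assay, at which 1 of the 3 values shown sits, and the same kind of change weakened compound 1 relative to compound 2. The estimate for compound 4 is therefore 170000 nM, most likely reported only as a limit.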

Compound 4, half-maximal inhibitory concentration: > 48000 nM
Compound 4 gave a limit, no number (the forecaster's own chance of this, stated with the estimate: 85%); the middle value is on the limit's open side.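

The step from compound 3 to compound 4 cannot be read, since both results are limits and not numbers: the limit of > 48000 nM in this assay, at which 2 of the 4 values shown sit.

As far as these compounds go, whether hydrogen in place of propyl changes anything for this pair in this assay therefore stays open.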